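Bromo for trifluoromethylsulfanyl on the phenyl of compound 3

The source may hold more compounds than are shown below. What is called first, only, known or untested is meant among the compounds shown, and "the series" means these compounds.

Three compounds of this series have been run in a functional assay on MCF7 cells (Homo sapiens) for antiproliferative activity, read by MTT assay; on this read-out higher numbers stand for weaker inhibition and lower numbers for stronger inhibition. Compound 1 `COc1ccc2nc(N(Cc3cc(-c4ccccc4F)no3)c3nc4ccc(F)cc4s3)sc2c1` gives 28500 nM, compound 2 `C#CCN(c1ncccn1)c1nc2ccccc2s1` gives 18300 nM, and compound 3 `FC(F)(F)Sc1ccc(-c2cc(CN(c3ncccn3)c3nc4ccccc4s3)on2)cc1` gives 17200 nM. The number for compound 3 is the lowest of the three shown, but its gaps to compound 2 and to compound 1 both lie within the scatter, so the three compounds cannot be told apart on these data; all sit in the weak range of this assay.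

Compound 4 `Brc1ccc(-c2cc(CN(c3ncccn3)c3nc4ccccc4s3)on2)cc1` differs from compound 3 in one place: bromo in place of (trifluoromethyl)sulfanyl on an aromatic carbon. No pair of measured compounds shows what such a change does in this assay, so no shown step can be drawn on. With compound 3 at 17200 nM and nothing to argue for a move in either direction, the expectation is a step from compound 3 to compound 4 of about a 1.2-fold higher number from compound 3 to compound 4 (0.07 log units; within the scatter), which is no change beyond the scatter. Compound 4 is therefore estimated at 20000 nM, with a range from 8000 nM to 50000 nM.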

Compound 4, half-maximal inhibitory concentration: 21100 nM
Compound 4: middle estimate off by 1.1-fold (0.02 log units), on the low side; measured number inside the range.
By their numbers in this assay, from the lowest: compounds 3, 2, 4 and 1 (each within the scatter of the next).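

In this assay, bromo in place of (trifluoromethyl)sulfanyl on an aromatic carbon of a six-membered aromatic ring of carbon only gives a 1.2-fold higher number from compound 3 to compound 4 (0.09 log units; within the scatter). For the compounds shown here, this is the first step that changes one place alone, and it shows that going from a group of 5 heavy atoms to one of 1 heavy atom does not move the number beyond the scatter. Both compounds stay in the weak range of this read-out, and no measured property of either group is available to interpret the step.

Going by these compounds, whether an amine or a carboxylic acid at this place would move the number beyond the scatter remains open. So does whether any change elsewhere on the shared core would lift the series out of the weak range.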